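A few compounds are considered here, and "the series" means these few. Any claim that something is new, unique, unknown or untested is made for them only; others in the source may bear on it.

Measured so far:
- compound 1, `CN(CCCn1ccnc1)C(=O)[C@@H]1CCCN1c1nccc(Nc2ccccc2)n1`: 4%
- compound 2, `CC(=O)CCCCC(=O)N1CCN(c2nccc(Oc3cccc(C)c3)n2)CC1`: 1%
- compound 3, `COC[C@@H]1CCCN1C(=O)C1CCCN1c1cc(Nc2cccc(Br)c2)ncn1`: 0%

The three compounds share a core and have been run in an assay on isolated protein for inhibition of vascular endothelial growth factor receptor 1 (Homo sapiens), read by HTRF, tested at 10 uM; a lower number here means less inhibition, a higher number more inhibition at the concentration tested (going by the name of the read-out). Compound 1 gives 4% in this assay, compound 2 gives 1%, and compound 3 gives 0%. The values of compound 1, compound 2 and compound 3 all lie within the scatter of one another, so none of the three can be told apart from the others on these numbers. Going by the values given here, no pair differing in one place has been measured, so nothing about the size of any single change is yet known from the data, and all three values sit at the low end of what this assay reports.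

Compound 4, `Cc1cccc(Oc2ccnc(N3CCN(C(=O)c4c(C)noc4C)CC3)n2)c1`, is the next to be tested. It differs from compound 2 as follows: 3,5-dimethyl-1,2-oxazol-4-yl in place of 4-acetylbutyl on a carbonyl carbon. Beyond the three numbers, nothing connects this change to a known outcome. Given the values of compound 1, compound 2 and compound 3, which lie within the scatter of one another, the expectation for compound 4 in this assay is a value near that of compound 2, with a step of a number 2 percentage points higher from compound 2 to compound 4 (within the scatter) expected not to exceed the scatter. Compound 4 is estimated at 3%, with a range from -5% to 12%.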

Compound 4, a percentage reported as inhibition, at one concentration (the size of the read-out at that concentration, not a potency): 7%
Estimate against measurement, compound 4: 4 percentage points below, within the range that was stated.
By their numbers in this assay, from the lowest: compounds 3, 2, 1 and 4 (each within the scatter of the next).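

Going by these compounds alone, on the carbonyl carbon whose other neighbour is the amide-type nitrogen in a ring, the first single-place comparison reads, in this assay, as a number 6 percentage points higher from compound 2 to compound 4 (within the scatter) for 3,5-dimethyl-1,2-oxazol-4-yl in place of 4-acetylbutyl. This position therefore accepts a five-membered aromatic ring with 2 hetero atoms instead of a chain with no ring, and the two compounds cannot be told apart in this assay, so this change gives no measurable gain or loss at the concentration tested. No independent measurement bears on this outcome.

Still open, on these data alone, is whether an amine, a carboxylic acid or a longer chain on this carbonyl carbon would give a number beyond the scatter of compound 2, since both groups compared so far leave the read-out near the low end of the assay. Also open, as far as these compounds go, is whether 3,5-dimethyl-1,2-oxazol-4-yl would give a comparable result on the core of compound 1, and whether any compound can be separated from the others.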